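The source may hold more compounds than are shown below. What is called first, only, known or untested is meant among the compounds shown, and "the series" means these compounds.

Measured so far in a functional assay on MGC-803 cells (Homo sapiens) for antiproliferative activity, read by CCK-8 assay, with a stated time of 72 h; on this read-out lower numbers stand for stronger inhibition and higher numbers for weaker inhibition
- compound 1 `O=C(/C=C/c1ccc(CN2CCc3ccccc32)cc1)NO` gives "not determined" (no result reported)
- compound 2 `Nc1ccccc1NC(=O)c1ccc(COc2ccccc2)cc1` gives 5670 nM
- compound 3 `Cc1ccc(OCc2ccc(C(=O)Nc3ccccc3N)cc2)cc1` gives 6530 nM

Compound 3 stands level with compound 2 in this assay and compound 1 offers no number for comparison. Compound 4 `CCCc1ccc(OCc2ccc(C(=O)Nc3ccccc3N)cc2)cc1` follows from compound 3 through ethyl in place of hydrogen on a saturated chain carbon bound to an aromatic carbon and this turns 4-methylphenyl to 4-propylphenyl. Among the compounds with values here, one measured step bears on it, methyl in place of hydrogen on an aromatic carbon, seen as a 1.2-fold higher number from compound 2 to compound 3 (0.06 log units; within the scatter) and so small. Within the data shown here, no measured compound carries a chain of this kind, which keeps the range wide. The expected change is a 1.1-fold lower number from compound 3 to compound 4 (0.04 log units; within the scatter) and no shift beyond the scatter is anticipated in either direction. Compound 4 is estimated at 6000 nM with an expected range of 2500 nM to 15000 nM in this assay.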

Compound 4, half-maximal inhibitory concentration: 4420 nM
Estimate against measurement, compound 4: 1.4-fold (0.13 log units) above, and the stated range covers the measured number.
By their numbers in this assay, from the lowest: compounds 4, 2 and 3 (each within the scatter of the next).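

In this assay the change from 4-methylphenyl to 4-propylphenyl gives a 1.5-fold lower number from compound 3 to compound 4 (0.17 log units; within the scatter) and the propyl chain, set against no group at all at this place, gives a 1.3-fold lower number from compound 2 to compound 4 (0.11 log units; within the scatter) in the same read-out. This position therefore accepts a propyl chain as well as a methyl group, and the number stays level across compounds 2, 3 and 4. No accompanying measurement offers an explanation for this flat response.

Still open, from the compounds shown here alone, is whether a longer chain, an amine or a carboxylic acid at this place would move the number beyond the scatter.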